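A few compounds are considered here, and "the series" means these few. Any claim that something is new, unique, unknown or untested is made for them only; others in the source may bear on it.

Measured in an ADME assay on HL-60 cells (Homo sapiens) for cytotoxicity, read by MTT assay, with a stated time of 24 h (a higher number here means a weaker inhibitor, a lower number a stronger inhibitor), so far:
- compound 1 `CN1CCC=C(c2ccc(CN(C)Cc3ccc(Cl)cc3)cc2)C1` gives > 50000 nM as a limit
- compound 2 `CC(C)CCN(C)Cc1ccc(C2CCCN(C)C2)cc1` gives > 50000 nM as a limit
- compound 3 `CN(Cc1ccc(Cl)cc1)Cc1ccc(C2CCCN(C)C2)cc1` gives > 50000 nM as a limit

Among the compounds with values here, compound 3 therefore has no number, only a limit, and the series so far shows (the limit of > 50000 nM in this assay, at which 3 of the 3 values shown sit). The change to compound 4 `CN(Cc1ccc(Cl)cc1)Cc1ccc(-c2cccnc2)cc1` is pyridin-3-yl in place of 1-methylpiperidin-3-yl on an aromatic carbon. Within the data shown here, two measured steps bear on it, (a step that the two limits leave unreadable from compound 1 to compound 3) and (a step that the two limits leave unreadable from compound 2 to compound 3), and neither has a readable size. Among the measured compounds shown here, the first also changes the group on an aromatic carbon. No direction follows from them, so no step beyond the scatter is expected in this assay, and another limit is the likely reading. The expected step is (a number no higher from compound 3 to compound 4 (the limit leaves the size open)). For compound 4 the estimated value is 50000 nM with an expected range from 20000 nM to 100000 nM in this assay.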

Compound 4, half-maximal inhibitory concentration: 21000 nM
Compound 4: the middle estimate sits 2.4-fold (0.38 log units) above what was measured; low and high end bracket the measured number.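

In this assay, within the data shown here, pyridin-3-yl in place of 1-methylpiperidin-3-yl on an aromatic carbon gives the only readable change so far: an at least 2.3-fold lower number from compound 3 to compound 4 (0.37 log units; beyond the scatter). The same group also gives a readable step against the group in the other ring-bearing compound: an at least 2.3-fold lower number from compound 1 to compound 4 (0.37 log units; beyond the scatter). The steps among the earlier compounds cannot be read, and most of the series remains at a limit rather than a number: the limit of > 50000 nM in this assay, at which 3 of the 4 values shown sit.

Open, going by these compounds, is whether phenyl or pyridin-4-yl in this place would shift the number in the same way. Also open, on these data alone, is whether the step holds with isobutyl in place of 4-chlorophenyl.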